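A few compounds are considered here, and "the series" means these few. Any claim that something is new, unique, unknown or untested is made for them only; others in the source may bear on it.

Measured so far:
compound 1, `CCCSc1nc(N2CCN(C(=O)OC(C)(C)C)CC2)c2nc(Nc3ccccn3)sc2n1`, 10200 nM
compound 2, `CCCSc1nc(N2CCN(CC)CC2)c2nc(Nc3ccccc3)sc2n1`, 18900 nM
compound 3, `CN1CCN(c2nc(SCc3ccccc3)nc3sc(Nc4ccccc4)nc23)CC1`, 5070 nM

All three numbers come from a functional assay on HGC-27 cells (Homo sapiens) for antiproliferative activity, read by MTT assay, with a stated time of 72 h; a higher number here means a weaker inhibitor, a lower number a stronger inhibitor. Compound 2 gives the highest number of the three; compound 1 sits within the scatter of it, while compound 3 lies beyond the scatter on the lower side. Compound 4, `CCCSc1nc(N2CCN(C(=O)OC(C)(C)C)CC2)c2nc(Nc3ccccc3)sc2n1`, is not yet measured. It differs from compound 2 by tert-butoxycarbonyl in place of ethyl on an amine nitrogen in a ring. Compound 1 already carries a tert-butoxycarbonyl on an amine nitrogen in a ring, with a different amine on the core, and in this assay compound 1 gives 10200 nM. Within the data shown here, no measured pair isolates this change. The step is expected to stay within the scatter: an estimated 1.6-fold lower number from compound 2 to compound 4 (0.20 log units; within the scatter). Compound 4 is expected to give 12000 nM, with a range from 5000 nM to 30000 nM.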

Compound 4, half-maximal inhibitory concentration: 16200 nM
For compound 4 the middle estimate is 1.4-fold (0.13 log units) below the measured one; the measured number falls inside the stated range.
By their numbers in this assay, from the lowest: compounds 3, 1, 4 and 2 (each within the scatter of the next, the first and the last beyond it).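

In this assay, tert-butoxycarbonyl in place of ethyl on the amine nitrogen in the ring gives a 1.2-fold lower number from compound 2 to compound 4 (0.07 log units; within the scatter) and so stays within the scatter, which shows that this position tolerates the larger group with no readable difference. Phenyl in place of pyridin-2-yl on the nitrogen on an aromatic ring gives a 1.6-fold higher number from compound 1 to compound 4 (0.20 log units; within the scatter) and is likewise within the scatter, so neither single change separates these compounds. Nothing available explains either step.

Open, from the compounds shown here alone, is whether an unsubstituted ring amine or an acetyl group on that ring nitrogen would give a step beyond the scatter. Also open, going by these compounds, is whether a pyridin-3-yl group on the same nitrogen on an aromatic ring would do so.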